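Series notes: removing the chloro group from compound 2

The source may hold more compounds than are shown below. What is called first, only, known or untested is meant among the compounds shown, and "the series" means these compounds.

Measured compounds:
- compound 1, `CCOC(=O)c1c(-c2c(Cl)c3ccccc3oc2=O)nn(-c2ccc(OC)cc2)c1C(=O)OCC`: 27000 nM
- compound 2, `CCOC(=O)c1c(-c2c(Cl)c3ccccc3oc2=O)nn(-c2cccc(Cl)c2)c1C(=O)OCC`: 40000 nM
- compound 3, `CCOC(=O)c1c(-c2c(Cl)c3cc(C)ccc3oc2=O)nn(-c2cccc(Cl)c2)c1C(=O)OCC`: 125000 nM

In a functional assay on HeLa cells (Homo sapiens) for cytotoxicity, read by MTT assay, with a stated time of 48 h (on this read-out lower numbers stand for stronger inhibition and higher numbers for weaker inhibition), compound 2 gives 40000 nM, the second highest of the three numbers. Its nearest neighbour is compound 1; the step of a 1.5-fold higher number from compound 1 to compound 2 (0.17 log units; within the scatter), a 3-chlorophenyl in place of 4-methoxyphenyl on an aromatic nitrogen, lies within the scatter. The step of a 3.1-fold higher number from compound 2 to compound 3 (0.49 log units; beyond the scatter), methyl in place of hydrogen on an aromatic carbon, is modest but beyond the scatter.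

Compound 4, `CCOC(=O)c1c(-c2cc3ccccc3oc2=O)nn(-c2cccc(Cl)c2)c1C(=O)OCC`, differs from compound 2 by hydrogen in place of chloro on an aromatic carbon, on an aromatic carbon of a six-membered aromatic ring with one oxygen, part of a fused system of two rings, ortho to a fused ring and to a large group, opposite the ring oxygen. Going by the values given here, neither measured step touches this position, so no directional guidance exists; the only change on the fused system, from compound 2 to compound 3, weakened the number modestly. The expected step of a 1.3-fold higher number from compound 2 to compound 4 (0.10 log units; within the scatter) is therefore small and uncertain in direction. Compound 4 is estimated at 50000 nM in this assay, within 15000 nM to 160000 nM.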

Compound 4, half-maximal inhibitory concentration: 22000 nM
The estimate for compound 4 lay 2.3-fold (0.36 log units) above the measured number; the measured number falls inside the stated range.
By their numbers in this assay, from the lowest: compounds 4, 1 and 2 (each within the scatter of the next); then compound 3.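

In this assay hydrogen in place of chloro on this aromatic carbon, opposite the ring oxygen, gives a 1.8-fold lower number from compound 2 to compound 4 (0.26 log units; within the scatter). Going by these compounds alone, compound 1, compound 2 and compound 3 all carry chloro here, so this step is the only reading of the position, and it shows that with 3-chlorophenyl on the aromatic nitrogen, the chloro group can be replaced by hydrogen without a step beyond the scatter. No measurement available here bears on this result or on what the chloro group does at this position.

As far as these compounds go, whether an amine, a methoxy group or a carboxylic acid on this carbon would give a step beyond the scatter remains open. Also open, from the compounds shown here alone, is whether the same replacement would stay within the scatter with 4-methoxyphenyl on the aromatic nitrogen or with the methyl group of compound 3 present.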